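The source may hold more compounds than are shown below. What is called first, only, known or untested is meant among the compounds shown, and "the series" means these compounds.

Measured so far:
Compound 1 `O=C(Nc1ccc(Cl)cc1)C(=O)N1CCC(c2ccnc3ccc(F)cc23)CC1`: 97 mL.min-1.g-1
Compound 2 `N#Cc1ccc(NC(=O)C(=O)N2CCC(c3ccnc4ccc(F)cc34)CC2)cc1`: 28 mL.min-1.g-1
Compound 3 `O=C(Nc1ccc(Cl)cn1)C(=O)N1CCC(c2ccnc3ccc(F)cc23)CC1`: 112 mL.min-1.g-1

All three numbers come from an ADME assay on microsomes from liver (Mus musculus) for metabolic stability; on this read-out higher numbers stand for fast clearance and lower numbers for slow clearance. In this set, compound 1 at 97 mL.min-1.g-1 lies within the scatter of compound 3 and sits clearly higher than compound 2.

Compound 4 `O=C(Nc1ccc(Cl)cc1)C(=O)N1CC[C@H](c2ccnc3ccc(F)cc23)[C@@H](O)C1` keeps the 4-chlorophenyl group of compound 1 and differs at a single place: hydroxy in place of hydrogen on a saturated ring carbon. The hydroxy stands on a saturated ring carbon, next to the ring atom that bears a large group.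

Going by the values given here, no measured step touches that ring, so the data offer no direct precedent. The steps that start at compound 1 change aromatic groups instead. Cyano in place of chloro gives a 3.5-fold lower number from compound 1 to compound 2 (0.54 log units; beyond the scatter), while 5-chloropyridin-2-yl in place of 4-chlorophenyl gives a 1.2-fold higher number from compound 1 to compound 3 (0.06 log units; within the scatter). The largest step among the three compounds is a 4.0-fold higher number from compound 2 to compound 3 (0.60 log units; beyond the scatter). These steps serve only as a scale, and they suggest a modest change rather than a large one. A downward move is expected, though its direction remains a judgement, with a 1.8-fold lower number from compound 1 to compound 4 (0.25 log units; within the scatter) as the estimated step. Compound 4 is expected at 55 mL.min-1.g-1, with an estimated range from 22 mL.min-1.g-1 to 120 mL.min-1.g-1.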

Compound 4, intrinsic clearance in microsomes: 17 mL.min-1.g-1
For compound 4 the middle estimate is 3.2-fold (0.51 log units) above the measured one, and the stated range ends above it.
By their numbers in this assay, from the lowest: compounds 4 and 2 (each within the scatter of the next); then compounds 1 and 3 (each within the scatter of the next).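

In this assay hydroxy in place of hydrogen on a saturated ring carbon, next to the ring atom that bears a large group, gives a 5.7-fold lower number from compound 1 to compound 4 (0.76 log units; beyond the scatter) and so shows that this ring of the shared core is a place where the number can move. The earlier steps shown here from compound 1 changed only aromatic groups, for example a 3.5-fold lower number from compound 1 to compound 2 (0.54 log units; beyond the scatter), whereas compound 4 keeps the 4-chlorophenyl group of compound 1 and still ends beyond the scatter of it. Nothing at hand bears on the reason for this lower number.

As far as these compounds go, it stays open whether the step belongs to the hydroxy itself or would also follow from a methoxy group, a fluorine atom or an amine on the same ring carbon. Also open, from the compounds shown here alone, is whether hydroxy would move the number in the same way alongside the 4-cyanophenyl group of compound 2 or the 5-chloropyridin-2-yl group of compound 3, and whether the mirror-image arrangement at the two substituted ring carbons would behave like compound 4.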